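This account rests on a few compounds, and the source may have more. Where it says the series, first, only, none or still open, it means among the compounds named here.

In a functional assay on A549 cells (Homo sapiens) for antiproliferative activity, read by MTT assay, with a stated time of 48 h (a higher number here means a weaker inhibitor, a lower number a stronger inhibitor), compound 1, `CN(C)CCCCn1c(N)c(-c2nc3ccccc3n2C)c2nc(C#N)c(C#N)nc21`, gives 6150 nM. Compound 2, `CCN(CC)CCn1c(N)c(-c2nc3cc(Cl)ccc3[nH]2)c2nc(C#N)c(C#N)nc21`, is reported only as a limit of this assay, namely > 50000 nM. Compound 2 therefore stands at the limit of > 50000 nM in this assay, at which 1 of the 2 values shown sits, and no number is known for it. Compound 3, `CN(C)CCCCn1c(N)c(-c2nc3cc(Cl)ccc3[nH]2)c2nc(C#N)c(C#N)nc21`, has not yet been measured in this assay. Compound 3 differs from compound 2 by 2-(dimethylamino)ethyl in place of diethylamino on a saturated chain carbon, two bonds along the chain from an aromatic nitrogen. Among the measured compounds shown here, no measured pair of compounds shows this same change, so the size of the step cannot be read from the numbers at hand; compound 1, which carries a 4-(dimethylamino)butyl chain, gives 6150 nM, which suggests that compounds with this chain can reach measurable inhibition. A moderate gain is expected, so the step from compound 2 to compound 3 is estimated as an at least 1.6-fold lower number from compound 2 to compound 3 (0.22 log units; that floor lies within the scatter). Compound 3 is expected to give about 30000 nM, within a range from 8000 nM to 100000 nM.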

Compound 3, half-maximal inhibitory concentration: 12100 nM
Compound 3: the middle estimate sits 2.5-fold (0.39 log units) above what was measured; the measured number falls inside the stated range.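

In this assay compound 2 remains a limit and not a number: the limit of > 50000 nM in this assay, at which 1 of the 3 values shown sits. Even so, the change to 2-(dimethylamino)ethyl in place of diethylamino, on a saturated chain carbon, two bonds along the chain from an aromatic nitrogen, now has a readable floor of an at least 4.1-fold lower number from compound 2 to compound 3 (0.61 log units; beyond the scatter), which shows that this position can carry a step beyond the scatter. The other step, a 2.0-fold higher number from compound 1 to compound 3 (0.29 log units; within the scatter), puts 5-chloro-1H-benzimidazol-2-yl in place of 1-methyl-1H-benzimidazol-2-yl on an aromatic carbon, and on the 4-(dimethylamino)butyl chain it does not separate these two groups.

Going by these compounds, it remains open whether the step follows the longer chain or the dimethylamino end, a question that a 4-(diethylamino)butyl chain on the same core would address. On these data alone, how a morpholine at the chain end, or a still longer chain, would read is also open.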